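Chloro for Trifluoromethyl in a Liver-Cell Cytotoxicity Series

The source may hold more compounds than are shown below. What is called first, only, known or untested is meant among the compounds shown, and "the series" means these compounds.

Compound 3 `CCOC(=O)CCCCCOc1cccc(CN(C(=O)c2ccc(-c3cccc(C(F)(F)F)c3)cc2)C(C)C)c1` carries a 3-(trifluoromethyl)phenyl group on the shared core. In an ADME assay on HepG2 cells (Homo sapiens) for cytotoxicity, read by CellTiter-Glo and resazurin assay, with a stated time of 72 h (a higher number here means that more compound is needed for the effect, a lower number that less compound is needed), compound 3 gives only a limit of the assay, > 26000 nM. Its two measured neighbours stand at the same limit. Compound 1 `CCOC(=O)CCCCCOc1cccc(CN(C(=O)c2ccc(-c3cccc(-c4ccccc4)c3)cc2)C(C)C)c1` gives the limit > 26000 nM in this assay. Compound 2 `CCOC(=O)CCCCCOc1cccc(CN(C(=O)c2ccc(-c3ccoc3)cc2)C(C)C)c1` gives the limit > 26000 nM in this assay. The whole measured set is thus summed up by the limit of > 26000 nM in this assay, at which 3 of the 3 values shown sit. The steps a step that the two limits leave unreadable from compound 1 to compound 2, a step that the two limits leave unreadable from compound 1 to compound 3 and a step that the two limits leave unreadable from compound 2 to compound 3 accordingly have no readable size, and the swaps of aryl groups they describe leave no trace in the numbers.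

Compound 4 `CCOC(=O)CCCCCOc1cccc(CN(C(=O)c2ccc(-c3cccc(Cl)c3)cc2)C(C)C)c1` differs from compound 3 by chloro in place of trifluoromethyl on an aromatic carbon. Among the measured compounds shown here, none of the measured steps bears a readable size on which an expectation for this change could rest, so the data give no ground for a shift in either direction. Compound 4 is therefore expected to show a step of a number no higher from compound 3 to compound 4 (the limit leaves the size open) in this assay, with the result most probably again reported as a limit rather than a number. The estimate for compound 4 in this assay is 26000 nM, between 13000 nM and 52000 nM.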

Compound 4, half-maximal effective concentration: > 18400 nM
Compound 4: a limit, no number; the forecaster's own chance of this, stated with the estimate: 85%; the middle value is on the limit's open side.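

In this assay compound 4 gives > 18400 nM, which is a limit and not a number. Among the compounds shown here, the values of compound 1, compound 2 and compound 3 are limits too, so no step from any of them to compound 4 can be read. The compounds shown leave open whether chloro in place of trifluoromethyl changes the half-maximal effective concentration at all.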